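The compounds below may be only part of what the source reports. "The series", "measured", "known", "first", "only" and "open" are said of these compounds alone.

Compound 1 `Cc1cc(NC(=O)C2C(C)(C)C2(C)C)ccc1N1CCC(N2CCCC2C)C1` and compound 2 `Cc1cc(NC(=O)C2CC3CCC2C3)ccc1N1CCC(N2CCCC2C)C1` share one core, and in an assay on CHO cells for displacement of a labelled ligand from histamine receptor H3 (Macaca mulatta) (on this read-out lower numbers stand for stronger inhibition and higher numbers for weaker inhibition), compound 1 gives 65.5 nM while compound 2 gives 130 nM. Between them stands a single change, (a group of 7 heavy atoms (7 carbon; 2 five-membered non-aromatic rings of carbon only) in place of a group of 7 heavy atoms (7 carbon; one three-membered non-aromatic ring of carbon only), on a carbonyl carbon), and the resulting step was a 2.0-fold higher number from compound 1 to compound 2 (0.30 log units; within the scatter).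

Compound 3 `Cc1cc(N2CC[C@H](N3CCC[C@@H]3C)C2)ccc1NC(=O)C1C(C)(C)C1(C)C` carries the same atoms as compound 1 joined differently; the difference between the two cores is not broken down here. In this assay compound 3 gives 0.55 nM, the lowest of the three numbers, with compound 1 at a higher number and compound 2 higher still, both gaps beyond the scatter.

Compound 4 `Cc1cc(N2CC[C@H](N3CCC[C@@H]3C)C2)ccc1NC(=O)C1CC2CCC1C2` is not yet measured. It arises from compound 3 by the same kind of change seen once before: a group of 7 heavy atoms (7 carbon; 2 five-membered non-aromatic rings of carbon only) in place of a group of 7 heavy atoms (7 carbon; one three-membered non-aromatic ring of carbon only), on a carbonyl carbon. The place line is identical in wording for both pairs, so the change is the same, only set on the core of compound 3 rather than that of compound 1.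

Given that the one earlier instance of this change produced a step from compound 1 to compound 2 of a 2.0-fold higher number from compound 1 to compound 2 (0.30 log units; within the scatter), the expectation for compound 4 is a step of similar size, estimated as a 2.0-fold higher number from compound 3 to compound 4 (0.30 log units; within the scatter) in this assay. On that basis compound 4 is expected to give about 1.1 nM in this assay, with a likely range from 0.4 nM to 3.5 nM. Whether the new core keeps the change so small remains to be seen.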

Compound 4, inhibition constant: 0.55 nM
Compound 4: the middle estimate sits 2.0-fold (0.30 log units) above what was measured, and the stated range covers the measured number.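

In this assay, putting the group with two five-membered carbon rings in place of 2,2,3,3-tetramethylcyclopropyl on the carbonyl carbon produced no change at the digits printed from compound 3 to compound 4 (within the scatter), so on the core of compound 3 the exchange leaves the read-out without any step beyond the scatter. Set beside the earlier instance on the core of compound 1, the change carries over from one core to the other as a step of matching size, and the two cores give no sign of treating it differently: the same change on two cores in this assay, a 2.0-fold higher number (0.30 log units; within the scatter) from compound 1 to compound 2 and no change at the digits printed (within the scatter) from compound 3 to compound 4, 2.0-fold (0.30 log units) apart, within the scatter of two such steps. Going by these compounds alone, this rests on only two pairs in a single assay, so it does not establish that the two groups are interchangeable on any further core, and it offers no explanation for why the exchange makes so little difference on these two.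

The compounds shown leave open how a phenyl ring, a longer alkyl chain, or a chain ending in an amine or a carboxylic acid would read on the carbonyl carbon of either core in this assay. They also leave open whether the match between the two steps would persist on histamine receptor H3 from another species.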